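Moving the nitro group: notes on compound 4

The compounds below may be only part of what the source reports. "The series", "measured", "known", "first", "only" and "open" are said of these compounds alone.

Compound 1 `COc1cc(C(=O)c2cn(-c3cccc(C)c3)cc2-c2cccc([N+](=O)[O-])c2)cc(OC)c1OC`, compound 2 `COc1cc(C(=O)c2cn(-c3cccc(C)c3)cc2-c2ccc([N+](=O)[O-])cc2)cc(OC)c1OC` and compound 3 `COc1cc(C(=O)c2cn(-c3ccc(F)cc3)cc2-c2cccc([N+](=O)[O-])c2)cc(OC)c1OC` are measured; compound 4 `COc1cc(C(=O)c2cn(-c3ccc(F)cc3)cc2-c2ccc([N+](=O)[O-])cc2)cc(OC)c1OC` is not yet measured. In a functional assay on MCF7 cells (Homo sapiens) for cytotoxicity, read by MTT assay, with a stated time of 96 h (a higher number here means a weaker inhibitor, a lower number a stronger inhibitor), compound 1 gives 880 nM, compound 2 gives 780 nM and compound 3 gives 440 nM. Compound 2 differs from compound 1 by 4-nitrophenyl in place of 3-nitrophenyl on an aromatic carbon, and that change made a 1.1-fold lower number from compound 1 to compound 2 (0.05 log units; within the scatter). Compound 3 differs from compound 1 by 4-fluorophenyl in place of 3-methylphenyl on an aromatic nitrogen, which gave a 2.0-fold lower number from compound 1 to compound 3 (0.30 log units; within the scatter). Compound 4 differs from compound 3 by 4-nitrophenyl in place of 3-nitrophenyl on an aromatic carbon. Among the measured compounds shown here, this is the same kind of change as the one from compound 1 to compound 2, not the same: around the place, the ring atom two ring bonds away bears a 4-fluorophenyl group in compound 3 and compound 4, whereas it bears a 3-methylphenyl group in compound 1 and compound 2. Resting on the earlier step of a 1.1-fold lower number from compound 1 to compound 2 (0.05 log units; within the scatter), which stayed within the scatter, the step of a 1.1-fold lower number from compound 3 to compound 4 (0.04 log units; within the scatter) in this assay is expected to be of similar, small size. Compound 4 is accordingly estimated at 400 nM, with a likely range from 200 nM to 800 nM.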

Compound 4, half-maximal inhibitory concentration: 240 nM
Compound 4: middle estimate off by 1.7-fold (0.22 log units), on the high side; the range from low to high includes it.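

In this assay, 4-nitrophenyl in place of 3-nitrophenyl gave a 1.8-fold lower number from compound 3 to compound 4 (0.26 log units; within the scatter), and this step does not differ from its counterpart on the core bearing 3-methylphenyl: the same change on two cores in this assay, a 1.1-fold lower number (0.05 log units; within the scatter) from compound 1 to compound 2 and a 1.8-fold lower number (0.26 log units; within the scatter) from compound 3 to compound 4, 1.6-fold (0.21 log units) apart, within the scatter of two such steps
4-Fluorophenyl in place of 3-methylphenyl on the ring nitrogen gave a 3.3-fold lower number from compound 2 to compound 4 (0.51 log units; beyond the scatter), and this step also does not differ from its earlier counterpart, although only this one lies beyond the scatter: the same change on two cores in this assay, a 2.0-fold lower number (0.30 log units; within the scatter) from compound 1 to compound 3 and a 3.3-fold lower number (0.51 log units; beyond the scatter) from compound 2 to compound 4, 1.6-fold (0.21 log units) apart, within the scatter of two such steps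
Each change therefore carried across these two cores with no difference that can be told from the scatter, but four compounds in one cell assay do not show that either change would carry to other cores, or that the two steps of a pair truly have the same size.

The compounds shown leave open whether this agreement holds with another group on the ring nitrogen, such as a longer chain ending in an amine. They also leave open how a carboxylic acid or a nitrile in place of the nitro group would behave on either core.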